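The source may report more compounds than this note shows. Statements on the series, on what has been measured and on what is new or still open speak of the compounds shown alone.

Of the compounds shown here, three have been read so far in a functional assay on K562 cells (Homo sapiens), read by MTT assay, with a stated time of 72 h; a higher number here means a weaker inhibitor, a lower number a stronger inhibitor. Compound 1 `O=c1[nH]cnc2c1c(-c1ccccc1)cn2[C@@H]1O[C@H](CO)[C@@H](O)[C@H]1O` gives > 20000 nM, which is a limit and not a number. Compound 2 `Nc1nc2c(c(-c3ccoc3)cn2[C@@H]2O[C@H](CO)[C@@H](O)[C@H]2O)c(=O)[nH]1` gives 19600 nM. Compound 3 `Nc1nc2c(c(-c3cccs3)cn2[C@@H]2O[C@H](CO)[C@@H](O)[C@H]2O)c(=O)[nH]1` gives > 20000 nM, again a limit and not a number. Compound 3 therefore has no number of its own and stands with the limit of > 20000 nM in this assay, at which 2 of the 3 values shown sit.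

Compound 4 `Nc1nc2c(c(-c3ccccc3)cn2[C@@H]2O[C@H](CO)[C@@H](O)[C@H]2O)c(=O)[nH]1` is the next to be read, and its structure departs from that of compound 3 by phenyl in place of thiophen-2-yl on an aromatic carbon. In short, the thiophen-2-yl group of compound 3 gives way to phenyl on the shared core.

Going by the values given here, only one measured step bears on this change, a swap of one aromatic group for another: an at least 1.0-fold higher number from compound 2 to compound 3 (0.00 log units; that floor lies within the scatter). Among the compounds with values here, that step shows no change that can be told from the scatter, and no measured step brings in phenyl on this core. The expectation therefore rests on that single step and on compound 2 at 19600 nM. In this assay the expected step is a step that the limit leaves unreadable from compound 3 to compound 4, an estimate that stays within the scatter and has no expected direction. A report of only a limit is also expected to be the likelier outcome. For compound 4 the estimated half-maximal inhibitory concentration is 22000 nM, with an expected range from 10000 nM to 50000 nM.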

Compound 4, half-maximal inhibitory concentration: > 20000 nM
Compound 4: only a limit was reported; the forecaster's own chance of this, stated with the estimate: 70%; the middle value is on the limit's open side.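

In this assay compound 4 gives > 20000 nM, which is a limit and not a number. Phenyl in place of furan-3-yl at this position gives an at least 1.0-fold higher number from compound 2 to compound 4 (0.00 log units; that floor lies within the scatter), so a six-membered aromatic ring of carbon only, like thiophen-2-yl before it, shows no change from furan-3-yl that can be told from the scatter. The steps from compound 3 and from compound 1 to compound 4 cannot be read, which leaves the amino group on the shared core without a measured effect, and the limit now covers a further compound on this core: the limit of > 20000 nM in this assay, at which 3 of the 4 values shown sit.

The compounds shown leave open whether any group on this aromatic carbon can give a value clearly lower than that of compound 2, at 19600 nM, as all the groups here are aromatic rings bonded directly to the core. An amine, a carboxylic acid or a longer chain at this position would test whether the series can move away from the limit at all.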